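Amide nitrogen substitution and solubility across the series

The source may hold more compounds than are shown below. What is called first, only, known or untested is meant among the compounds shown, and "the series" means these compounds.

Compound 3 `CNC(=O)c1cc(C(N)=O)cn(Cc2ccccc2)c1=O` is the reference point. Among the measured compounds shown here, in a physicochemical assay for solubility (a lower number here means a less soluble compound, a higher number a more soluble compound), compound 3 gives 71 ug/mL, the only plain number among the three measured compounds. Compound 1 `CNC(=O)c1cc(C(=O)NCCC2CCOCC2)cn(Cc2ccccc2)c1=O` reached the assay limit, >= 127 ug/mL (the limit of >= 127 ug/mL in this assay, at which 1 of the 3 values shown sits). Compound 2 `CNC(=O)c1cc(C(=O)NC)c(=O)n(Cc2ccccc2)c1` likewise reached an assay limit, >= 118 ug/mL (the limit of >= 118 ug/mL in this assay, at which 1 of the 3 values shown sits).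

The step from compound 1 to compound 2 reads a step that the two limits leave unreadable from compound 1 to compound 2. The two steps ending at compound 3 both carry only a floor: an at least 1.7-fold lower number from compound 1 to compound 3 (0.25 log units; that floor lies within the scatter) and an at least 1.6-fold lower number from compound 2 to compound 3 (0.22 log units; that floor lies within the scatter). Each floor lies within the scatter, so the true size of these steps is not fixed, though both point downward as the amide nitrogen loses its substituent.

Compound 4 `CNC(=O)c1cc(C(=O)NCCOC)cn(Cc2ccccc2)c1=O` differs from compound 3 by 2-methoxyethyl in place of hydrogen on an amide-type nitrogen. This runs opposite to the steps ending at compound 3, where a substituent left the amide nitrogen. The number for compound 4 is therefore expected to rise, a 1.7-fold higher number from compound 3 to compound 4 (0.23 log units; within the scatter), quite possibly up to the assay limit. The estimate for compound 4 is 120 ug/mL, in the range 70 ug/mL to 200 ug/mL.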

Compound 4, solubility: >= 164 ug/mL
Compound 4 ended at the assay's limit; the forecaster's own chance of this, stated with the estimate: 45%; middle value at least 1.3-fold (0.13 log units) away from the limit.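

In this assay, among the compounds shown here, 2-methoxyethyl in place of hydrogen on an amide-type nitrogen gives an at least 2.3-fold higher number from compound 3 to compound 4 (0.36 log units; beyond the scatter), the only step at this position printed as beyond the scatter, whereas the two earlier steps ending at compound 3 carried floors within it. Compound 4 gives >= 164 ug/mL, which is a limit of the assay. The steps among compound 1, compound 2 and compound 4 join limits and cannot be read, so methyl, 2-(oxan-4-yl)ethyl and 2-methoxyethyl on this nitrogen remain unranked.

Open, as far as these compounds go, is how a plain butyl chain, a 2-(dimethylamino)ethyl chain or a chain ending in a carboxylic acid on this nitrogen would compare with hydrogen in this assay. Also open, from the compounds shown here alone, is how far above their limits the substituted amides lie.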